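Swapping isopropyl for propyl on the shared core

A few compounds are considered here, and "the series" means these few. Any claim that something is new, unique, unknown or untested is made for them only; others in the source may bear on it.

Within the data shown here, in a functional assay on HepG2 cells (Homo sapiens) for antiproliferative activity, read by MTT assay, with a stated time of 48 h (on this read-out lower numbers stand for stronger inhibition of growth and higher numbers for weaker inhibition of growth), compound 1 `Cc1ccc(-c2cnc(N(Cc3ccccc3)Cc3ccc(C(=O)NO)cc3)s2)cc1` gives 34000 nM and compound 2 `Cc1ccc(-c2cnc(N(Cc3ccc(C(=O)NO)cc3)C(C)C)s2)cc1` gives 2180 nM, the lower of the only two numbers available. Among the measured compounds shown here, the one measured step, a 16-fold lower number from compound 1 to compound 2 (1.19 log units; beyond the scatter), is large and beyond the scatter, and it puts isopropyl in place of benzyl on a nitrogen on an aromatic ring. Compound 3 `CCCN(Cc1ccc(C(=O)NO)cc1)c1ncc(-c2ccc(C)cc2)s1` differs from compound 2 at that same nitrogen, with propyl in place of isopropyl on a nitrogen on an aromatic ring. The measured step removed a benzyl group, whereas here no ring leaves or enters, so its size offers little guide and no step beyond the scatter is expected in this assay. The expected change is a 1.1-fold higher number from compound 2 to compound 3 (0.06 log units; within the scatter), with little confidence in its direction. For compound 3 the estimated value is 2500 nM, with an expected range from 900 nM to 8000 nM.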

Compound 3, concentration for 50% growth inhibition: 2550 nM
The estimate for compound 3 lay 1.0-fold (0.01 log units) below the measured number, within the range that was stated.
By their numbers in this assay, from the lowest: compounds 2 and 3 (each within the scatter of the next); then compound 1.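

In this assay, isopropyl and propyl have the same count of carbon atoms, and a 1.2-fold higher number from compound 2 to compound 3 (0.07 log units; within the scatter) shows that joining those atoms differently on this nitrogen does not separate the two compounds. With ethyl in place of phenyl on the saturated chain carbon bound to the nitrogen, a 13-fold lower number from compound 1 to compound 3 (1.12 log units; beyond the scatter) adds a second large step away from compound 1, so both replacements that leave no ring on this nitrogen give far lower numbers than the benzyl group of compound 1. No measurement here explains either step.

The compounds shown leave open whether a shorter chain such as methyl or a longer chain such as butyl would give numbers close to those of compound 2 and compound 3. They also leave open how a chain ending in an amine or a carboxylic acid would behave at this nitrogen.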